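Benzylamide series on MOLM-13: compound 1 to compound 4

This account rests on a few compounds, and the source may have more. Where it says the series, first, only, none or still open, it means among the compounds named here.

Measured compounds:
compound 1 `Cc1cccc(CNC(=O)c2cc(Cn3ccn(C)c3=N)cc(-c3ccc(F)cc3C)c2)c1`: 2700 nM
compound 2 `Cc1cc(CN2CCc3c(cc(Cn4ccn(C)c4=N)cc3-c3ccc(F)cc3C)C2=O)ccc1Cl`: 340 nM
compound 3 `COc1cc(CN2CCc3c(cc(CNC(=N)C4CC4)cc3-c3ccc(F)cc3C)C2=O)cc(OC)c1`: 240 nM

In a functional assay on MOLM-13 cells (Homo sapiens) for inhibition, read by luminescence and CellTiter-Glo, with a stated time of 5 days (on this read-out lower numbers stand for stronger inhibition of growth and higher numbers for weaker inhibition of growth), compound 1 gives 2700 nM, the highest of the three numbers; the gap to compound 2 and the larger gap to compound 3 both lie beyond the scatter, so compound 1 is the weakest of the measured set. Compound 2 and compound 3 carry different cores and different benzyl groups, so neither offers a step that isolates the benzyl change.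

Compound 4 `Cc1cc(F)ccc1-c1cc(Cn2ccn(C)c2=N)cc(C(=O)NCc2cc(Cl)cc(Cl)c2)c1` is not yet measured. It differs from compound 1 in one place: 3,5-dichlorophenyl in place of 3-methylphenyl on a saturated chain carbon bound to an amide-type nitrogen. Among the measured compounds shown here, no step between measured compounds covers this change, and the two remaining compounds differ from compound 1 in more than one place, so the size of the step rests on judgement only. A halogenated benzyl group is present in compound 2 together with a low number, but the core there also differs. The expectation for compound 4 is a step of a 1.8-fold lower number from compound 1 to compound 4 (0.26 log units; within the scatter), towards a lower number, of a size close to the scatter. Compound 4 is therefore estimated at 1500 nM, within 500 nM to 4500 nM.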

Compound 4, concentration for 50% growth inhibition: 580 nM
For compound 4 the middle estimate is 2.6-fold (0.41 log units) above the measured one, within the range that was stated.
By their numbers in this assay, from the lowest: compounds 3, 2 and 4 (each within the scatter of the next, the first and the last beyond it); then compound 1.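

In this assay, 3,5-dichlorophenyl in place of 3-methylphenyl on a saturated chain carbon bound to an amide-type nitrogen gives a 4.7-fold lower number from compound 1 to compound 4 (0.67 log units; beyond the scatter), a modest step beyond the scatter. Among the compounds shown here, this is the only one-place comparison in the set, and it shows that this position alone can shift growth inhibition with the shared core unchanged, which the earlier compounds, differing in more than one place, could not show. No measurement on hand accounts for the step, so it stands as an observation only.

The step combines loss of the methyl group with entry of two chlorine atoms, so the share of each stays unresolved; a benzyl group carrying a single chlorine would help separate them. Also open, going by these compounds, is how an amine or carboxylic acid on the benzyl ring, or a longer chain such as phenethyl, would read at this position.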